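Dropping the Benzyl Methyl in a Sulfonyl Guanidine Series

A few compounds are considered here, and "the series" means these few. Any claim that something is new, unique, unknown or untested is made for them only; others in the source may bear on it.

Among the measured compounds shown here, compound 3 `Cc1cc(S(=O)(=O)/N=C(\N)n2nccc2-c2ccccc2)c(SCc2ccccc2C)cc1Cl` gives 17000 nM in a functional assay on HeLa cells (Homo sapiens) for cytotoxicity, read by MTT assay, with a stated time of 72 h (a higher number here means a weaker inhibitor, a lower number a stronger inhibitor), the second highest of the three numbers measured so far. Its nearest neighbour is compound 2 `Cc1cc(-c2ccccc2)n(/C(N)=N/S(=O)(=O)c2cc(C)c(Cl)cc2SCc2cccc3ccccc23)n1`, which in this assay gives 3000 nM; the furthest is compound 1 `Cc1cc(-c2ccccc2)n(/C(N)=N/S(=O)(=O)c2cc(C)c(Cl)cc2SCc2ccccc2C)n1`, which in this assay gives 160000 nM. Compound 4 `Cc1cc(S(=O)(=O)/N=C(\N)n2nccc2-c2ccccc2)c(SCc2ccccc2)cc1Cl` differs from compound 3 by hydrogen in place of methyl on an aromatic carbon, which cut one bond further out reads as 2-methylbenzyl to benzyl. For the measured compounds named here, no measured step removes this particular methyl, so two steps bear on it only loosely. The change from compound 1 to compound 3, a 9.4-fold lower number from compound 1 to compound 3 (0.97 log units; beyond the scatter), is the same kind of exchange but at another aromatic carbon, on the shared core rather than on the benzyl group. The change a 53-fold lower number from compound 1 to compound 2 (1.73 log units; beyond the scatter) alters the same benzylsulfanyl region, yet by a far larger swap than the loss of a single carbon. Going by the values given here, because the closest precedent a 9.4-fold lower number from compound 1 to compound 3 (0.97 log units; beyond the scatter) is modest and sits elsewhere, only a small step, in either direction and possibly within the scatter, is expected here. Compound 4 is therefore estimated at 15000 nM, with a range of 5000 nM to 50000 nM. This amounts to an expected step of a 1.1-fold lower number from compound 3 to compound 4 (0.05 log units; within the scatter).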

Compound 4, half-maximal inhibitory concentration: 5000 nM
Compound 4: the middle estimate sits 3.0-fold (0.48 log units) above what was measured; measured number inside the range.
By their numbers in this assay, from the lowest: compounds 2 and 4 (each within the scatter of the next); then compound 3; then compound 1.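

In this assay, among the compounds shown here, the step of a 3.4-fold lower number from compound 3 to compound 4 (0.53 log units; beyond the scatter) gives the first direct reading at this position, and taking the methyl off the benzyl group lowers the number beyond the scatter, a modest change of the same kind as a 9.4-fold lower number from compound 1 to compound 3 (0.97 log units; beyond the scatter) at the other aromatic carbon. For the compounds shown here, the benzylsulfanyl region also now shows something the earlier compounds could not: moving away from 2-methylbenzyl lowered the number both when a carbon was lost here and when naphthalen-1-yl entered in a 53-fold lower number from compound 1 to compound 2 (1.73 log units; beyond the scatter), although those two changes were read on different cores, so the 2-methylbenzyl group gave the higher number in both pairs. No measurement at hand accounts for either step.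

The compounds shown leave open whether this step is tied to methyl in particular or would also appear with another group on the same aromatic carbon, such as ethyl, methoxy or chlorine. They also leave open whether hydrogen in place of methyl at this position would give a step of similar size on the core of compound 1, which carries the second methyl.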